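A few compounds are considered here, and "the series" means these few. Any claim that something is new, unique, unknown or untested is made for them only; others in the source may bear on it.

Compounds measured so far:
compound 1, `CCOC(=O)c1cnn2c1N(C(=O)Nc1ccccc1F)C(c1ccccc1)C2`: 116 nM
compound 2, `CCOC(=O)c1cnn2c1N(C(=O)Nc1ccc(F)cc1)C(c1ccccc1)C2`: 10.3 nM

For the measured compounds named here, in a functional assay on cells (Neutrophil, Homo sapiens) for inhibition, with a stated time of 10 min (a lower number here means a stronger inhibitor, a higher number a weaker inhibitor), compound 2 holds the lowest of the two numbers; the sole measured step, an 11-fold lower number from compound 1 to compound 2 (1.05 log units; beyond the scatter), sets it well apart from compound 1, beyond the scatter. Compound 3, `CCOC(=O)c1cnn2c1N(C(=O)Nc1cccc3ccccc13)C(c1ccccc1)C2`, is the next member: naphthalen-1-yl in place of 4-fluorophenyl on an amide-type nitrogen. Going by the values given here, only the step from compound 1 to compound 2 bears on this change, and only loosely, since it compares two fluorophenyl isomers rather than a fused bicyclic group; it does show, however, that the aryl group on the amide-type nitrogen can move this assay by a large amount. The swap to naphthalen-1-yl is a bigger structural change than that, so a shift of moderate size, towards a higher number, is expected, a 5.8-fold higher number from compound 2 to compound 3 (0.77 log units; beyond the scatter). The estimate for compound 3 is 60 nM, with a range from 15 nM to 250 nM.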

Compound 3, half-maximal inhibitory concentration: 13.8 nM
Beside the measured number, compound 3's estimate is 4.3-fold (0.64 log units) above it; the whole stated range lies above it.
By their numbers in this assay, from the lowest: compounds 2 and 3 (each within the scatter of the next); then compound 1.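

In this assay, a 1.3-fold higher number from compound 2 to compound 3 (0.13 log units; within the scatter) shows that naphthalen-1-yl can stand in for 4-fluorophenyl on the amide-type nitrogen with no change beyond the scatter, so this position tolerates two six-membered aromatic rings as well as one, and a number at this level does not depend on fluorine. The same group set against 2-fluorophenyl gives an 8.4-fold lower number from compound 1 to compound 3 (0.92 log units; beyond the scatter) and leaves the 2-fluorophenyl member apart from the other two, beyond the scatter, in this small set. No measurement on hand accounts for either step.

From the compounds shown here alone, whether an aromatic group is needed on this nitrogen at all remains open, as a cyclohexyl or a short alkyl chain would test that. Also open, going by these compounds, is how a carboxylic acid or an amine on the aryl ring would read here.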